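Aryl variation on the ring nitrogen: compound 3 to compound 4

The compounds below may be only part of what the source reports. "The series", "measured", "known", "first", "only" and "open" are said of these compounds alone.

Compound 1 `COC(=O)c1c(-c2cc3ccccc3oc2=O)nn(-c2ccccc2)c1C(=O)OC` gives 30000 nM in a functional assay on DU-145 cells (Homo sapiens) for cytotoxicity, read by MTT assay, with a stated time of 48 h; a lower number here means a stronger inhibitor, a higher number a weaker inhibitor. Compound 2 `COC(=O)c1c(-c2cc3ccccc3oc2=O)nn(-c2cccc(C)c2)c1C(=O)OC` gives 35000 nM in this assay, and compound 3 `COC(=O)c1c(-c2cc3ccccc3oc2=O)nn(-c2cccc(F)c2)c1C(=O)OC` gives 37000 nM. Compound 3 carries the highest of the three numbers, yet the steps of a 1.2-fold higher number from compound 1 to compound 3 (0.09 log units; within the scatter) and a 1.1-fold higher number from compound 2 to compound 3 (0.02 log units; within the scatter) both fall within the scatter, as does a 1.2-fold higher number from compound 1 to compound 2 (0.07 log units; within the scatter). Compound 4 `COC(=O)c1c(-c2cc3ccccc3oc2=O)nn(-c2ccc(Br)cc2)c1C(=O)OC` differs from compound 3 in one place: 4-bromophenyl in place of 3-fluorophenyl on an aromatic nitrogen. All three measured steps alter the group on that same aromatic nitrogen, and none moved the number in this assay beyond the scatter, so the expected 1.1-fold lower number from compound 3 to compound 4 (0.02 log units; within the scatter) is likewise taken to stay within the scatter. Compound 4 is accordingly estimated at 35000 nM, with a range from 15000 nM to 80000 nM.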

Compound 4, half-maximal inhibitory concentration: 93000 nM
For compound 4 the middle estimate is 2.7-fold (0.42 log units) below the measured one; the measured number lies above the stated range.
By their numbers in this assay, from the lowest: compounds 1, 2 and 3 (each within the scatter of the next); then compound 4.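

The group on the aromatic nitrogen can move the number in this assay: 4-bromophenyl gives a 2.5-fold higher number from compound 3 to compound 4 (0.40 log units; beyond the scatter), a 2.7-fold higher number from compound 2 to compound 4 (0.42 log units; beyond the scatter) and a 3.1-fold higher number from compound 1 to compound 4 (0.49 log units; beyond the scatter), whereas the earlier changes at this position all stayed within the scatter. This position is therefore not indifferent to the aryl group, and this change goes towards a weaker inhibitor. Nothing available explains the shift.

Going by these compounds, whether the step follows from the bromo group itself or from where it sits on the phenyl ring remains open. On these data alone, how an amine or a carboxylic acid on that ring would read in this assay is also open.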